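Swapping chloro for methyl on the arylsulfonamide of compound 2

A few compounds are considered here, and "the series" means these few. Any claim that something is new, unique, unknown or untested is made for them only; others in the source may bear on it.

This account follows a single change made to compound 2 `O=C(O)CC/C=C\C[C@H]1[C@H](F)CC[C@@H]1NS(=O)(=O)c1ccc(Cl)cc1`. Among the compounds with values here, in a functional assay on a cell-free system (plasma) for inhibition of thromboxane A2 receptor (Homo sapiens), read by turbidimetry (on this read-out higher numbers stand for weaker inhibition and lower numbers for stronger inhibition), compound 2 gives 210 nM, the only number available for it, with one further entry that yields no single number. For comparison, compound 1 `O=C(O)CCC/C=C\CC1=CCC[C@@H]1NS(=O)(=O)c1ccc(F)cc1`, with a different core, gives 4400 nM; 4400 nM (2 entries) in this assay. The new compound, compound 3 `Cc1ccc(S(=O)(=O)N[C@H]2CC[C@@H](F)[C@@H]2C/C=C\CCC(=O)O)cc1`, differs from compound 2 by methyl in place of chloro on an aromatic carbon, with nothing else altered in the chain, the core or the carboxylic acid. Within the data shown here, no pair of measured compounds shows this particular change, so its size cannot be read from the numbers at hand. The expectation is a modest step, if any, from compound 2 to compound 3 in this assay, with no clear direction beyond the scatter, estimated at a 1.9-fold higher number from compound 2 to compound 3 (0.28 log units; within the scatter). Compound 3 is therefore expected to give about 400 nM, within a range from 150 nM to 1200 nM.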

Compound 3, half-maximal inhibitory concentration: 1900 nM
For compound 3 the middle estimate is 4.8-fold (0.68 log units) below the measured one; measured number outside the range, above it.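

In this assay, the place on the aromatic ring para to a large group proves sensitive to this swap: putting methyl in place of chloro gives a 9.0-fold higher number from compound 2 to compound 3 (0.96 log units; beyond the scatter) and so weaker inhibition with 4-methylphenyl than with 4-chlorophenyl. The two groups count the same under the computed comparison, with one heavy atom each, no ring, no hydrogen-bond donors or acceptors and no net charge, so those counts do not separate them, although the read-out does. Nothing available explains why the step is this large.

Going by these compounds, whether bromo, methoxy or trifluoromethyl in the same place would sit nearer compound 2 or compound 3 remains open. Also open, on these data alone, is whether the same swap would give a step of similar size on the core of compound 1 or with a longer chain.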